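Plasma half-life in the hydroxamate series: carbamate cap

The source may hold more compounds than are shown below. What is called first, only, known or untested is meant among the compounds shown, and "the series" means these compounds.

Going by the values given here, compound 1 `CC[C@H](C)[C@H](NC(=O)CC(C)(C)C)C(=O)N1Cc2cc(OCC(=O)NO)ccc2C[C@H]1C(=O)Nc1ccc(N(C)C)cc1` stands highest of the two numbers so far in an ADME assay on a cell-free system (plasma, Rattus norvegicus) for metabolic stability, read by HPLC (on this read-out higher numbers stand for a longer-lived compound and lower numbers for a shorter-lived compound), where compound 1 gives 10.5 h. Compound 2 `CN(C)c1ccc(NC(=O)[C@@H]2Cc3ccc(OCC(=O)NO)cc3CN2C(=O)CNC(=O)CC(C)(C)C)cc1` gives 1.13 h in this assay. Among the compounds with values here, the single measured step, a 9.3-fold lower number from compound 1 to compound 2 (0.97 log units; beyond the scatter), is a modest one and concerns the hydrogen in place of sec-butyl on a saturated chain carbon bound to an amide-type nitrogen and a carbonyl carbon.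

Compound 3 `CC[C@H](C)[C@H](NC(=O)OC(C)(C)C)C(=O)N1Cc2cc(OCC(=O)NO)ccc2C[C@H]1C(=O)Nc1ccc(N(C)C)cc1` differs from compound 1 elsewhere: tert-butoxy in place of neopentyl on a carbonyl carbon. Cut one bond further out, the same difference reads neopentylcarbonyl to tert-butoxycarbonyl. The sec-butyl group that the measured step removed is kept in compound 3. Within the data shown here, no measured step touches the carbonyl cap, so nothing so far bears directly on this change, and the swap keeps the size of the group with one hydrogen-bond acceptor added. The expectation is therefore a step in this assay that stays within the scatter, with no firm direction. Compound 3 is expected to give 8 h, with a range from 3 h to 20 h. The step this estimate means is a 1.3-fold lower number from compound 1 to compound 3 (0.12 log units; within the scatter).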

Compound 3, half-life: 2.18 h
Compound 3: the middle estimate sits 3.7-fold (0.56 log units) above what was measured; the measured number lies below the stated range.
By their numbers in this assay, from the lowest: compounds 2 and 3 (each within the scatter of the next); then compound 1.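

The carbonyl cap is not a silent position in this assay: with the sec-butyl group kept, tert-butoxy in place of neopentyl on a carbonyl carbon gives a 4.8-fold lower number from compound 1 to compound 3 (0.68 log units; beyond the scatter) and so lies beyond the scatter. The series now holds two steps beyond the scatter, one at the sec-butyl carbon and one at this cap, and both lead down from compound 1. This second step comes with no change in heavy-atom count: neopentyl and tert-butoxy each carry 5 heavy atoms, and the exchange of one carbon for one oxygen adds one hydrogen-bond acceptor. No evidence at hand accounts for the shorter half-life of compound 3.

Whether the cap step holds without the sec-butyl group stays open, as the tert-butoxycarbonyl cap is shown here only with that group in place. Also open, on these data alone, is where other caps on this carbonyl carbon, such as an ethylamino group or a cyclohexyl ring, would fall on this read-out.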